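A few compounds are considered here, and "the series" means these few. Any claim that something is new, unique, unknown or untested is made for them only; others in the source may bear on it.

Among the compounds with values here, in an ADME assay on HT-29 cells (Homo sapiens) for cytotoxicity, read by MTT assay, with a stated time of 72 h (on this read-out lower numbers stand for stronger inhibition and higher numbers for weaker inhibition), compound 2 `COc1ccc(C2=C(c3cc(OC)c(OC)c(OC)c3)C(=O)C(O[SiH2]C(C)(C)C)C2)cc1OC(C)C` gives 9 ug/mL, the only exact number so far. Compound 1 `C=CCOc1cc(C2=C(c3cc(OC)c(OC)c(OC)c3)C(=O)C(O)C2)ccc1OC` gives > 100 ug/mL, which is a limit of the assay and not a number.

The next molecule, compound 3 `COc1ccc(C2=C(c3cc(OC)c(OC)c(OC)c3)C(=O)C(O)C2)cc1OC(C)C`, differs from compound 2 in one place: a hydrogen atom in place of a group of 5 heavy atoms (4 carbon, 1 silicon; no ring), on an oxygen on a saturated carbon. The change sits on an oxygen on a saturated carbon, so the silicon-containing group is lost and that oxygen carries a hydrogen instead.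

Within the data shown here, no measured pair shows this exact change on its own. The nearest guide is compound 1, which also has the hydrogen on that oxygen but differs from compound 3 elsewhere. Compound 1 reads > 100 ug/mL, again a limit of the assay and not a number. On that basis, a clear weakening beyond the usual scatter is expected for the step of a 5.6-fold higher number from compound 2 to compound 3 (0.74 log units; beyond the scatter). For compound 3, the estimated value is 50 ug/mL, with an expected range of 15 ug/mL to 150 ug/mL.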

Compound 3, half-maximal inhibitory concentration: > 100 ug/mL
Compound 3 gave a limit, no number; the forecaster's own chance of this, stated with the estimate: 40%; middle value at least 2.0-fold (0.30 log units) away from the limit.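

Replacing the silicon-containing group with a hydrogen atom on this oxygen on a saturated carbon gives an at least 11-fold higher number from compound 2 to compound 3 (1.04 log units; beyond the scatter) in this assay, so within this pair the measurable reading depends on that group being present. The true size of this step cannot be given, only its lower bound, since compound 3 sits at a limit of the assay and not at a number: the limit of > 100 ug/mL in this assay, at which 2 of the 3 values shown sit. The step between isopropyl and allyl on an oxygen on an aromatic ring cannot be read, as compound 1 and compound 3 both give limits.

The compounds shown leave open whether the silicon itself matters, or whether an all-carbon group such as a neopentyl chain on this oxygen would serve equally well. From the compounds shown here alone, it also remains open how a smaller methyl or an acetyl group there would read.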